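A few compounds are considered here, and "the series" means these few. Any claim that something is new, unique, unknown or untested is made for them only; others in the source may bear on it.

For the measured compounds named here, compound 2 `O=C(/C=C/c1cc([N+](=O)[O-])ccc1Cl)/C=C/c1ccccc1Oc1ncnc2ccc(Cl)cc12` gives 1960 nM in a functional assay on MGC-803 cells (Homo sapiens) for inhibition, read by MTT assay, with a stated time of 72 h (on this read-out lower numbers stand for stronger inhibition and higher numbers for weaker inhibition), the lowest of the two numbers measured so far; compound 1 `O=C(/C=C/c1ccc(Cl)c([N+](=O)[O-])c1)/C=C/c1ccccc1Oc1ncnc2ccc(Cl)cc12` gives 5320 nM. Compound 3 `O=C(/C=C/c1ccccc1Oc1ncnc2ccc(Cl)cc12)/C=C/c1c(Cl)cccc1Cl` differs from compound 2 by 2,6-dichlorophenyl in place of 2-chloro-5-nitrophenyl on a double-bonded chain carbon bound to a double-bonded chain carbon. Going by the values given here, the one measured step, a 2.7-fold lower number from compound 1 to compound 2 (0.43 log units; beyond the scatter), altered the same ring but only rearranged its chlorine and nitro substituents, so it bears only loosely on a change that removes the nitro group altogether. Compound 3 is therefore expected to stay close to its parent, a step of a 1.5-fold higher number from compound 2 to compound 3 (0.18 log units; within the scatter), with wide uncertainty. The estimate for compound 3 is 3000 nM, ranging from 1000 nM to 10000 nM.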

Compound 3, half-maximal inhibitory concentration: 5170 nM
Estimate against measurement, compound 3: 1.7-fold (0.24 log units) below; measured number inside the range.
By their numbers in this assay, from the lowest: compound 2; then compounds 3 and 1 (each within the scatter of the next).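

Swapping the nitro-bearing ring at this position for 2,6-dichlorophenyl does not leave the number unchanged in every case: in this assay, the swap gives a 2.6-fold higher number from compound 2 to compound 3 (0.42 log units; beyond the scatter). Made from the other nitro-bearing ring, 4-chloro-3-nitrophenyl, the same swap gives a 1.0-fold lower number from compound 1 to compound 3 (0.01 log units; within the scatter), so a nitro group is not needed to reach that level. Nothing available explains either step. Still open, going by these compounds, is how this position responds to an unsubstituted phenyl ring, or to an amine in place of the nitro group.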